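Replacing the Isopropyl Amide of Compound 3 with Methoxycarbonyl

The compounds below may be only part of what the source reports. "The series", "measured", "known", "first", "only" and "open" are said of these compounds alone.

Measured compounds:
Compound 1, `COc1cc(/C=C/C(=O)c2cccc(NC(=O)c3ccco3)c2)ccc1O`: in a functional assay on HUVEC cells (Homo sapiens) for inhibition, tested at 10 ug/mL (on this read-out higher numbers stand for a stronger effect at the one concentration tested and lower numbers for a weaker effect), compound 1 gives 100%.
Compound 2, `COc1cc(/C=C/C(=O)c2cccc(NC(=O)c3ccc(Cl)cc3Cl)c2)ccc1O`: compound 2 gives 70%.
Compound 3, `COc1cc(/C=C/C(=O)c2cccc(NC(=O)C(C)C)c2)ccc1O`: compound 3 gives 56%.

Within this set of three, compound 3 stands lowest. The two steps that lead to it both run downward: a number 44 percentage points lower from compound 1 to compound 3 (beyond the scatter) and a number 14 percentage points lower from compound 2 to compound 3 (beyond the scatter), while the step between the two higher compounds, a number 30 percentage points lower from compound 1 to compound 2 (beyond the scatter), is smaller. All three differences sit on the same carbonyl carbon of the amide, so the group on that carbon is what separates the three numbers.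

Compound 4, `COC(=O)C(=O)Nc1cccc(C(=O)/C=C/c2ccc(O)c(OC)c2)c1`, continues at the same position. Its difference from compound 3 is methoxycarbonyl in place of isopropyl on a carbonyl carbon.

Among the compounds with values here, none of the measured steps replaces isopropyl with a group of this kind; the measured exchanges put furan-2-yl or 2,4-dichlorophenyl, both rings, in place of isopropyl, and both gave higher numbers. Methoxycarbonyl carries no ring, so the measured steps offer only a loose guide. The expectation is therefore a step of uncertain direction, most likely within or near the scatter, with a wide range: compound 4 is estimated to show a number 4 percentage points higher from compound 3 to compound 4 (within the scatter) in this assay, giving an expected value of 60%, between 35% and 85%.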

Compound 4, a percentage reported as inhibition, at one concentration (the size of the read-out at that concentration, not a potency): 43%
For compound 4 the middle estimate is 17 percentage points above the measured one; low and high end bracket the measured number.
By their numbers in this assay, from the lowest: compound 4; then compound 3; then compound 2; then compound 1.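

In this assay, within the data shown here, methoxycarbonyl is the first group on this carbonyl carbon to fall below isopropyl, with a number 13 percentage points lower from compound 3 to compound 4 (beyond the scatter) and so compound 3 no longer marks the bottom of the series. The same exchange sits further under the two groups that carry a ring, with a number 27 percentage points lower from compound 2 to compound 4 (beyond the scatter) and with a number 57 percentage points lower from compound 1 to compound 4 (beyond the scatter) as the largest step seen at this position, so that among these four compounds the two groups without a ring hold the two lowest numbers and no compound goes against that split. No measurement shown accounts for this order.

On these data alone, whether a ring as such is what matters stays open, since only furan-2-yl and 2,4-dichlorophenyl represent the ring side, and a plain phenyl or a thiophen-2-yl on the same carbonyl carbon would show how far that split holds. As far as these compounds go, on the side without a ring, it also stays open how a carboxylic acid, a primary amide or a longer chain in place of methoxycarbonyl would stand against isopropyl on this read-out.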